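This account rests on a few compounds, and the source may have more. Where it says the series, first, only, none or still open, it means among the compounds named here.

Compound 1 `CC(C)=CCC/C=C(\C)Cc1c(OC/C=C(\C)CCC=C(C)C)cc(O)c2c(=O)cc(-c3ccccc3)oc12` carries two 3,7-dimethylocta-2,6-dien-1-yl groups on its core. In a functional assay on HT-29 cells (Homo sapiens) for cytotoxicity, read by XTT assay, with a stated time of 72 h (on this read-out higher numbers stand for weaker inhibition and lower numbers for stronger inhibition), compound 1 gives only a limit, > 100000 nM. Compound 2 `CC(=O)c1c(O)cc(O)c2c1OC(C)(C)CC2` likewise reaches only a limit in this assay, > 100000 nM. Compound 3 `C=C1CC[C@H]2C(C)(C)CCC[C@]2(C)[C@H]1CC/C(C)=C/COc1cc(O)c2c(=O)c(O)c(-c3ccc(O)cc3)oc2c1` also gives only a limit in this assay, > 100000 nM. Thus every value shown sits at the same limit (the limit of > 100000 nM in this assay, at which 3 of the 3 values shown sit), and compound 1 stands nowhere apart from the others. Compound 4 `CC(C)=CCC/C=C(\C)Cc1c(O)cc(O)c2c(=O)cc(-c3ccccc3)oc12` differs from compound 1 in one place (hydrogen in place of 3,7-dimethylocta-2,6-dien-1-yl on an oxygen on an aromatic ring). Among the measured compounds shown here, with no measured step to build on, the writer expects no step beyond the usual scatter for compound 4, a number no higher from compound 1 to compound 4 (the limit leaves the size open). He therefore estimates compound 4 at 100000 nM in this assay, between 30000 nM and 300000 nM, most likely again as a limit.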

Compound 4, half-maximal inhibitory concentration: 32000 nM
Compound 4: the middle estimate sits 3.1-fold (0.49 log units) above what was measured; the measured number falls inside the stated range.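

In this assay, hydrogen in place of 3,7-dimethylocta-2,6-dien-1-yl on an oxygen on an aromatic ring gives an at least 3.1-fold lower number from compound 1 to compound 4 (0.49 log units; beyond the scatter). Among the compounds shown here, this shows that the number responds to a change at this position, which the earlier compounds, all at one limit, could not show. Compound 1 gives only a limit, > 100000 nM, and the full size of the step stays unknown: the limit of > 100000 nM in this assay, at which 3 of the 4 values shown sit.

As far as these compounds go, whether a shorter chain such as methyl on that oxygen would also give a lower number remains open. So does the effect of an amine in place of the hydroxy.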